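Carbamoyl in Place of Hydroxyacetyl on the Piperidine Nitrogen

This account rests on a few compounds, and the source may have more. Where it says the series, first, only, none or still open, it means among the compounds named here.

Compound 2 `Cc1ccccc1C(=O)Nc1ccc(S(=O)(=O)NC2CCN(C(=O)CO)CC2)c2ccccc12` gives 5.4 nM in an assay on L1.2 cells for binding affinity to C-C chemokine receptor type 8 (Homo sapiens) (a lower number here means a stronger inhibitor, a higher number a weaker inhibitor), the lower of the two single numbers at hand. Its nearest neighbour, compound 1 `CCOC(=O)N1CCC(NS(=O)(=O)c2ccc(NCc3ccccc3)c3ccccc23)CC1`, gives 45.6 nM, a gap that lies beyond the usual scatter. Compound 3 `Cc1ccccc1C(=O)Nc1ccc(S(=O)(=O)NC2CCN(C(=O)[C@@H]3CCCN3)CC2)c2ccccc12` has no single number but several entries, 0.7 nM; 1 nM (2 entries), gathered as the several entries of compound 3 in this assay, 0.7 nM; 1 nM (2 entries). Within the data shown here, no two measured compounds differ in one place only. Compound 4 `Cc1ccccc1C(=O)Nc1ccc(S(=O)(=O)NC2CCN(C(N)=O)CC2)c2ccccc12` differs from compound 2 by amino in place of hydroxymethyl on a carbonyl carbon. Among the measured compounds shown here, with no measured step of this kind to lean on, the change is expected to shift the number little, and the step from compound 2 to compound 4 is estimated as a 1.5-fold higher number from compound 2 to compound 4 (0.17 log units; within the scatter). Compound 4 is therefore expected to give about 8 nM in this assay, within a range from 3 nM to 25 nM.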

Compound 4, inhibition constant: 243 nM
Beside the measured number, compound 4's estimate is 30-fold (1.48 log units) below it; the measured number lies above the stated range.
By their numbers in this assay, from the lowest: compound 2; then compound 1; then compound 4.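

In this assay, amino in place of hydroxymethyl on the carbonyl carbon brings a 45-fold higher number from compound 2 to compound 4 (1.65 log units; beyond the scatter), so this position responds strongly to an exchange of two heavy atoms for one. The carbonyl alone therefore does not secure a low number, and the group it carries matters. Compound 3, with another group on the same carbonyl carbon, keeps low numbers: the several entries of compound 3 in this assay, 0.7 nM; 1 nM (2 entries)

The compounds shown leave open whether the rise follows the amino nitrogen sitting directly on the carbonyl carbon or the missing carbon. An aminomethyl or a methylamino group at this place would separate the two.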